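Aryl amide retained: dichlorophenyl replaces cyanophenyl

The source may hold more compounds than are shown below. What is called first, only, known or untested is meant among the compounds shown, and "the series" means these compounds.

Compound 2 `N#Cc1cccc(C(=O)Nc2c(C(O)(C(F)(F)F)C(F)(F)F)ccc3ccccc23)c1` gives the lowest number seen in an assay on LtK cells with ATP-sensitive inward rectifier potassium channel 11 (Homo sapiens) as the target (a higher number here means that more compound is needed for the effect, a lower number that less compound is needed), 12 nM; compound 1 `CCC(C)C(=O)Nc1c(C(O)(C(F)(F)F)C(F)(F)F)ccc2ccccc12` gives 177000 nM. Among the measured compounds shown here, the only measured step is a 15000-fold lower number from compound 1 to compound 2 (4.17 log units; beyond the scatter), which shows how much an aromatic ring on the carbonyl carbon matters. Compound 3 `O=C(Nc1c(C(O)(C(F)(F)F)C(F)(F)F)ccc2ccccc12)c1cccc(Cl)c1Cl` keeps that aromatic ring: 2,3-dichlorophenyl in place of 3-cyanophenyl on a carbonyl carbon. For the measured compounds named here, no measured step separates two aryl groups here, so the expected change for compound 3 is estimated as modest, a 2.5-fold higher number from compound 2 to compound 3 (0.40 log units; beyond the scatter), because a 15000-fold lower number from compound 1 to compound 2 (4.17 log units; beyond the scatter) arose from losing the aryl, not from varying it. Compound 3 is therefore expected near 30 nM, within 5 nM to 200 nM.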

Compound 3, half-maximal effective concentration: > 10000 nM
Compound 3 was reported as a limit; the forecaster's own chance of this, stated with the estimate: 3%; at least 330-fold (2.52 log units) between middle value and limit.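

Having an aromatic ring on the carbonyl carbon is therefore not enough in this assay, since which ring sits there also counts, with an at least 830-fold higher number from compound 2 to compound 3 (2.92 log units; beyond the scatter). Compound 3 is reported only as a limit, not as a number: the limit of > 10000 nM in this assay, at which 1 of the 3 values shown sits. The step from compound 1 to compound 3 cannot be read, so the sec-butyl and 2,3-dichlorophenyl groups cannot be ranked against each other.

The compounds shown leave open whether the change follows from losing the nitrile or from gaining the chlorine atoms. A plain phenyl group on the carbonyl carbon would bear on that question.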